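A few compounds are considered here, and "the series" means these few. Any claim that something is new, unique, unknown or untested is made for them only; others in the source may bear on it.

Measured so far:
compound 1, `N=C(S)CCn1ncccc1=S`: 100 mg/kg
compound 2, `Cc1ccc(=S)n(CCC(=N)S)n1`: 100 mg/kg
compound 3, `CC(CC(=N)S)n1ncccc1=O`: > 100 mg/kg

The read-out throughout is a functional assay on the whole organism (stomach) with Rattus norvegicus as the target; on this read-out lower numbers stand for an effect already at smaller amounts and higher numbers for an effect only at larger amounts of compound. In this assay compound 1 gives 100 mg/kg. Compound 2 differs from compound 1 by methyl in place of hydrogen on an aromatic carbon, and in this assay compound 2 gives 100 mg/kg. The step of no change at the digits printed from compound 1 to compound 2 (within the scatter) is flat. For compound 3 this assay returns a limit, > 100 mg/kg, and not a number. The difference between the core of compound 1 and the core of compound 3 is not broken down here.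

Compound 4, `Cc1ccc(=O)n(C(C)CC(=N)S)n1`, is not yet measured. It stands to compound 3 as compound 2 stands to compound 1: methyl in place of hydrogen on an aromatic carbon. The surroundings of the place are not identical in the two pairs: in compound 3 the entering methyl is meta to a group of 6 heavy atoms, in compound 1 meta to a group of 5 heavy atoms, so this is the same kind of change, not the same change.

For the step from compound 3 to compound 4 a flat outcome is expected, a step that the limit leaves unreadable from compound 3 to compound 4, resting on the flat step no change at the digits printed from compound 1 to compound 2 (within the scatter) seen for the same kind of change. The value of compound 4 in this assay is accordingly estimated at 150 mg/kg, expected to lie between 60 mg/kg and 400 mg/kg. Because compound 3 sits at the limit of > 100 mg/kg in this assay, at which 1 of the 3 values shown sits, there is a fair chance that compound 4 will also come back as a limit rather than a number.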

Compound 4, dose for half-maximal effect: > 100 mg/kg
Compound 4: a limit, no number; the forecaster's own chance of this, stated with the estimate: 65%; the middle value lies beyond the limit too.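

In this assay, compound 3 and compound 4 both return limits and not numbers, so no step can be read between them: the limit of > 100 mg/kg in this assay, at which 2 of the 4 values shown sit.

The compounds shown leave open whether methyl in place of hydrogen on an aromatic carbon changes anything on the core of compound 3 in this assay, and how that core compares with the core of compound 1.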